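Swapping methoxy for trifluoromethyl on the aryl ketone

The source may report more compounds than this note shows. Statements on the series, on what has been measured and on what is new or still open speak of the compounds shown alone.

Measured so far:
compound 1 `COc1cc(-c2nnc3n2NC(c2ccco2)C(C(=O)c2ccc(Br)cc2)S3)cc(OC)c1OC` — 36400 nM
compound 2 `COc1cc(-c2nnc3n2NC(c2ccco2)C(C(=O)c2cccs2)S3)cc(OC)c1OC` — 46200 nM
compound 3 `COc1ccc(C(=O)C2Sc3nnc(-c4cc(OC)c(OC)c(OC)c4)n3NC2c2ccco2)cc1` — > 100000 nM (a limit of the assay)

In a functional assay on PC-3 cells (Homo sapiens) for cytotoxicity, read by MTT assay, with a stated time of 48 h (on this read-out higher numbers stand for weaker inhibition and lower numbers for stronger inhibition), compound 3 stands at the weak end of the three: its result > 100000 nM is a limit of the assay and not a number. Compound 4 `COc1cc(-c2nnc3n2NC(c2ccco2)C(C(=O)c2ccc(C(F)(F)F)cc2)S3)cc(OC)c1OC` has not yet been measured; it differs from compound 3 in one place only: trifluoromethyl in place of methoxy on an aromatic carbon. For the measured compounds named here, two measured steps bear on this. The closest is an at least 2.7-fold higher number from compound 1 to compound 3 (0.43 log units; beyond the scatter), in which bromo on that aromatic carbon gave the lower number and methoxy gave the limit. The second is an at least 2.1-fold higher number from compound 2 to compound 3 (0.33 log units; beyond the scatter), where thiophen-2-yl on the carbonyl carbon likewise gave a lower number than the methoxy-bearing ring. Both measured departures from the methoxy-bearing group lowered the number, so replacing methoxy with trifluoromethyl is expected to lower it too, by about an at least 2.0-fold lower number from compound 3 to compound 4 (0.30 log units; that floor lies within the scatter). Compound 4 is therefore estimated at 50000 nM, with a range from 15000 nM to 150000 nM. Since compound 3 is known only as a limit, the size of this expected step is uncertain.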

Compound 4, half-maximal inhibitory concentration: 77500 nM
Compound 4: the middle estimate sits 1.6-fold (0.19 log units) below what was measured; the range from low to high includes it.
By their numbers in this assay, from the lowest: compounds 1, 2 and 4 (each within the scatter of the next, the first and the last beyond it). At a limit, above all of these: compound 3.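

Trifluoromethyl on this aromatic carbon gives a 2.1-fold higher number from compound 1 to compound 4 (0.33 log units; beyond the scatter) against bromo in this assay, so these two groups can be told apart here, if only modestly, while against the thiophen-2-yl ketone the result is a 1.7-fold higher number from compound 2 to compound 4 (0.22 log units; within the scatter). Against methoxy the step is an at least 1.2-fold lower number from compound 3 to compound 4 (0.11 log units; that floor lies within the scatter), so the ring with trifluoromethyl gives a real number, but that floor alone does not separate the two groups. Compound 3 stands at a limit of the assay and not at a number: the limit of > 100000 nM in this assay, at which 1 of the 4 values shown sits.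

On these data alone, what an amine, a hydroxyl or a carboxylic acid on this same carbon would give remains open. So does the true size of the step from methoxy to trifluoromethyl, and these compounds offer no cause for any of the differences.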